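Swapping the phenylthio substituent on a shared diamine core

This account rests on a few compounds, and the source may have more. Where it says the series, first, only, none or still open, it means among the compounds named here.

Measured so far in a functional assay on SNB-19 cells (Homo sapiens) for inhibition, read by sulforhodamine B assay, with a stated time of 48 h; on this read-out higher numbers stand for weaker inhibition of growth and lower numbers for stronger inhibition of growth:
- compound 1, `Nc1cc(N)c2nc(-c3ccccc3)c(Oc3ccc(Cl)c(Cl)c3)nc2c1`: 20900 nM
- compound 2, `COc1ccc(Sc2nc3cc(N)cc(N)c3nc2-c2ccccc2)cc1`: < 100000 nM

Compound 1 gives 20900 nM in this assay. Compound 2 is known only as a limit of this assay, < 100000 nM, so its true position is not fixed. Going by the values given here, the single measured step, a step that the limit leaves unreadable from compound 1 to compound 2, is therefore unreadable, as the evidence the limit of < 100000 nM in this assay, at which 1 of the 2 values shown sits, shows. The next compound, compound 3 with structure `Nc1cc(N)c2nc(-c3ccccc3)c(Sc3ccc(Cl)c(Cl)c3)nc2c1`, arises from compound 2 by the change (3,4-dichlorophenyl in place of 4-methoxyphenyl on a sulfur). Among the compounds with values here, compound 3 thus carries the sulfur link of compound 2 together with the 3,4-dichlorophenyl ring of compound 1, but no measured step quantifies either part. The expected result for compound 3 is placed near that of compound 1, and the change a step that the limit leaves unreadable from compound 2 to compound 3 is expected to be hard to read against a limit. Compound 3 is estimated at 25000 nM, with a likely range from 6000 nM to 100000 nM.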

Compound 3, concentration for 50% growth inhibition: 17000 nM
For compound 3 the middle estimate is 1.5-fold (0.17 log units) above the measured one, and the stated range covers the measured number.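

In this assay, (3,4-dichlorophenyl)sulfanyl in place of 3,4-dichlorophenoxy on an aromatic carbon gives a 1.2-fold lower number from compound 1 to compound 3 (0.09 log units; within the scatter), so on this read-out compound 1 and compound 3 cannot be told apart, and at this position the change of linking atom alone has no effect that stands out from the scatter. Compound 2 is known only as a limit, < 100000 nM. The steps that touch compound 2 therefore cannot be read, and the swap of 4-methoxyphenyl for 3,4-dichlorophenyl on a sulfur has no size yet: the limit of < 100000 nM in this assay, at which 1 of the 3 values shown sits.

Still open, from the compounds shown here alone, is how 4-methoxyphenyl truly compares with 3,4-dichlorophenyl on this sulfur, which would take a number for compound 2 in place of a limit. Also open, going by these compounds, is whether an amine or a carboxylic acid on this ring, or a longer chain in place of the ring, would shift the value beyond the scatter.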